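Methoxy-bearing quinoline sulfone: from nitrile to dimethylphenyl

A few compounds are considered here, and "the series" means these few. Any claim that something is new, unique, unknown or untested is made for them only; others in the source may bear on it.

Compounds measured so far:
compound 1 `Cc1ccc2ncc(S(=O)(=O)c3cccc(C#N)c3)c(N3CCC(C)CC3)c2c1` — 52%
compound 2 `COc1ccc2ncc(S(=O)(=O)c3cccc(C#N)c3)c(N3CCC(C)CC3)c2c1` — 90%
compound 3 `CCN(CC)c1c(S(=O)(=O)c2ccc(C)cc2)cnc2ccccc12` — 78.3%

Of the compounds shown here, three have been tested in an assay on isolated protein for displacement of a labelled ligand from metabotropic glutamate receptor 5 (Homo sapiens), with a stated time of 60 min, tested at 1 uM; a higher number here means more inhibition at the concentration tested (going by the name of the read-out), a lower number less inhibition. Compound 2 gives 90% and stands highest of the three numbers; compound 3 is nearest with 78.3%, and compound 1 is furthest with 52%. For the measured compounds named here, the one step between compounds that differ in a single place runs a number 38 percentage points higher from compound 1 to compound 2 (beyond the scatter), a large rise for methoxy in place of methyl on an aromatic carbon of the shared core.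

Compound 4 `COc1ccc2ncc(S(=O)(=O)c3cc(C)cc(C)c3)c(N3CCC(C)CC3)c2c1` is not yet measured. It keeps the methoxy and the amine of compound 2 and changes only the group on the sulfonyl sulfur: 3,5-dimethylphenyl in place of 3-cyanophenyl on a sulfonyl sulfur. Going by the values given here, no measured step concerns this part of the molecule; the step from compound 1 to compound 2 is on the core and gives no direct guide. Compound 3 differs from compound 2 in several places at once; still, compound 3 shows with 78.3% that a sulfonyl-linked ring without a nitrile can go with substantial inhibition.

Among the compounds with values here, with no step of its own kind to lean on, compound 4 is expected to keep most of the inhibition of compound 2, at an estimated 78%, within 55% to 95%. That estimate means an expected step of a number 12 percentage points lower from compound 2 to compound 4 (beyond the scatter).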

Compound 4, a percentage reported as inhibition, at one concentration (the size of the read-out at that concentration, not a potency): 79%
Estimate against measurement, compound 4: 1 percentage points below, and the stated range covers the measured number.
By their numbers in this assay, from the lowest: compound 1; then compounds 3 and 4 (each within the scatter of the next); then compound 2.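

In this assay, the group on the sulfonyl sulfur proves to matter: 3,5-dimethylphenyl in place of 3-cyanophenyl gives a number 11 percentage points lower from compound 2 to compound 4 (beyond the scatter), the first step read at this position and a smaller one than a number 38 percentage points higher from compound 1 to compound 2 (beyond the scatter) on the core. The nitrile is not needed for substantial inhibition in this pair, since compound 4, which carries only carbon in the entering group, still gives 79% at the single concentration tested, although that figure is not a potency. No measurement shown here accounts for the difference between the two aryl groups.

As far as these compounds go, this single exchange removes the nitrile and adds two methyl groups at once, so it remains open whether the step follows from losing the nitrile, from gaining the methyl groups, or from both, and a phenyl ring with a single methyl group would begin to separate these. From the compounds shown here alone, it is also open whether the step would keep its size with the methyl group of compound 1 on the core, or with a morpholine in place of the amine of compound 2.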